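The source may report more compounds than this note shows. Statements on the series, on what has been measured and on what is new or still open speak of the compounds shown alone.

Measured so far in a functional assay on the whole organism (Hindlimb, strain albino) with Mus musculus as the target, in the maximal electroshock model, with a stated time of 0.5 h; on this read-out lower numbers stand for an effect already at smaller amounts and higher numbers for an effect only at larger amounts of compound:
compound 1, `Cc1ccc2nc(NC(=O)/C=C/OC3=CC=C3)sc2c1`, gives 505 umol/kg
compound 2, `O=C(/C=C/c1ccccc1)Nc1nc2ccccc2s1`, gives 646 umol/kg
compound 3, `Cc1ccc2nc(NC(=O)/C=C/c3ccccc3)sc2c1`, gives 380 umol/kg

All three values lie within the usual scatter of one another, so no order among them can be read from these numbers. The step of a 1.7-fold lower number from compound 2 to compound 3 (0.23 log units; within the scatter) and the step of a 1.3-fold higher number from compound 3 to compound 1 (0.12 log units; within the scatter) both stay within that scatter.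

Compound 4, `O=C(/C=C/OC1=CC=C1)Nc1nc2ccccc2s1`, has not yet been measured in this assay. It is derived from compound 2 by the change (a group of 5 heavy atoms (4 carbon, 1 oxygen; one four-membered non-aromatic ring of carbon only) in place of a group of 6 heavy atoms (6 carbon; one six-membered aromatic ring of carbon only), on a double-bonded chain carbon bound to a double-bonded chain carbon). The same change has already been made once among the measured compounds, from compound 3 to compound 1: a group of 5 heavy atoms (4 carbon, 1 oxygen; one four-membered non-aromatic ring of carbon only) in place of a group of 6 heavy atoms (6 carbon; one six-membered aromatic ring of carbon only), on a double-bonded chain carbon bound to a double-bonded chain carbon. The place of the change is described in the same words for both pairs, so it is the same change on the same kind of site. What differs is the core: compound 2 and compound 3 differ by hydrogen in place of methyl on an aromatic carbon, and that core difference on its own gave a 1.7-fold lower number from compound 2 to compound 3 (0.23 log units; within the scatter).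

Because the earlier step of a 1.3-fold higher number from compound 3 to compound 1 (0.12 log units; within the scatter) stayed within the scatter, the step from compound 2 to compound 4 is expected to be of similar size, about a 1.3-fold higher number from compound 2 to compound 4 (0.10 log units; within the scatter). Compound 4 is therefore estimated to give around 820 umol/kg in this assay. For compound 4 the expected range runs from 420 umol/kg to 1600 umol/kg. This rests on one matched pair only, so the expectation is correspondingly loose.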

Compound 4, dose for half-maximal effect: 781 umol/kg
For compound 4 the middle estimate is 1.0-fold (0.02 log units) above the measured one; low and high end bracket the measured number.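

In this assay, phenyl replaced by the group of 5 heavy atoms with its four-membered non-aromatic ring gives a step within the scatter (a 1.2-fold higher number from compound 2 to compound 4 (0.08 log units; within the scatter)), and this change reads alike on the two cores: the same change on two cores in this assay, a 1.3-fold higher number (0.12 log units; within the scatter) from compound 3 to compound 1 and a 1.2-fold higher number (0.08 log units; within the scatter) from compound 2 to compound 4, 1.1-fold (0.04 log units) apart, within the scatter of two such steps. The core change also reads alike with either group in place, with hydrogen in place of methyl on an aromatic carbon giving a 1.5-fold higher number from compound 1 to compound 4 (0.19 log units; within the scatter) here: the same change on two cores in this assay, a 1.7-fold lower number (0.23 log units; within the scatter) from compound 2 to compound 3 and a 1.5-fold lower number (0.19 log units; within the scatter) from compound 4 to compound 1, 1.1-fold (0.04 log units) apart, within the scatter of two such steps. For the compounds shown here, these four compounds therefore show that the two changes carry from one core to the other without any detectable interaction, but every step lies within the scatter, so they do not show that either change shifts the read-out, and they give no order among the compounds or any test of transfer for a step large enough to read clearly.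

The compounds shown leave open how other groups on the double-bonded chain carbon, such as an amine, a carboxylic acid or a longer chain, would read in this assay, and whether any of them would give a step beyond the scatter. They also leave open whether chlorine or methoxy on the aromatic carbon that carries hydrogen or methyl here would behave the same way on either side of the phenyl exchange.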